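The source may report more compounds than this note shows. Statements on the series, on what has been measured and on what is new or still open speak of the compounds shown alone.

Measured compounds in a functional assay on T47D cells (Homo sapiens) for antiproliferative activity, read by MTT assay, with a stated time of 72 h; a lower number here means a stronger inhibitor, a higher number a weaker inhibitor:
compound 1 `O=C(Nc1ccc(Cl)c(-c2nnc3c(Cl)cccn23)c1)c1cccc(Cl)c1`, giving 30200 nM
compound 2 `O=C(Nc1ccc(Cl)c(-c2nnc3c(Cl)cccn23)c1)c1ccccc1Cl`, giving 83800 nM
compound 3 `O=C(Nc1ccc(Cl)c(-c2nnc3c(Cl)cccn23)c1)c1ccon1`, for which the assay reports only a limit, > 100000 nM

Among the two values that are numbers, compound 1 stands lowest; its nearest neighbour is compound 2, and the step of a 2.8-fold higher number from compound 1 to compound 2 (0.44 log units; beyond the scatter) lies beyond the scatter. The limit for compound 3 is the same as the one noted in the limit of > 100000 nM in this assay, at which 1 of the 3 values shown sits.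

The unmeasured compound 4 `O=C(Nc1ccc(Cl)c(-c2nnc3c(Cl)cccn23)c1)c1cccnc1Cl` differs from compound 1 by one change: 2-chloropyridin-3-yl in place of 3-chlorophenyl on a carbonyl carbon. For the measured compounds named here, two measured steps bear on it. The step of a 2.8-fold higher number from compound 1 to compound 2 (0.44 log units; beyond the scatter) shows that shifting the chlorine from 3-chlorophenyl to 2-chlorophenyl on the carbonyl carbon gives a modestly higher number, and the step of an at least 3.3-fold higher number from compound 1 to compound 3 (0.51 log units; beyond the scatter) shows that replacing 3-chlorophenyl with a heteroaromatic ring, 1,2-oxazol-3-yl, also raises the number, at least modestly. Compound 4 combines a chlorine placed as in 2-chlorophenyl with a nitrogen in the ring, so a higher number than compound 1 is expected in this assay, of roughly the size seen for compound 2, possibly reaching the limit.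

Compound 4 is therefore estimated to give 90000 nM in this assay, within a range of 35000 nM to 250000 nM. This expectation corresponds to the step of a 3.0-fold higher number from compound 1 to compound 4 (0.47 log units; beyond the scatter).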

Compound 4, half-maximal inhibitory concentration: > 100000 nM
Compound 4 was reported as a limit; the forecaster's own chance of this, stated with the estimate: 40%; middle value at least 1.1-fold (0.04 log units) from the limit.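

In this assay, on a carbonyl carbon whose other neighbour is an amide-type nitrogen, 2-chloropyridin-3-yl in place of 3-chlorophenyl gives an at least 3.3-fold higher number from compound 1 to compound 4 (0.51 log units; beyond the scatter), so a second group with a ring nitrogen, after 1,2-oxazol-3-yl, fails to match 3-chlorophenyl. Set against 2-chlorophenyl, the same group gives an at least 1.1-fold higher number from compound 2 to compound 4 (0.07 log units; that floor lies within the scatter), so the data cannot separate what the ring nitrogen adds from what the chlorine placement in 2-chlorophenyl already costs, and the step from the 1,2-oxazol-3-yl compound cannot be read, as both values are limits. The value for compound 4 is a limit, the second one in this small set: the limit of > 100000 nM in this assay, at which 2 of the 4 values shown sit.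

Every group shown here is an aromatic ring, so what an amine, a carboxylic acid or a saturated ring such as piperidine would give on this carbonyl carbon stays open. Also open, from the compounds shown here alone, is whether a pyridine ring with its chlorine placed as in 3-chlorophenyl would keep the number of compound 1, 30200 nM, or lose it.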